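The source may hold more compounds than are shown below. What is called first, only, known or untested is meant among the compounds shown, and "the series" means these compounds.

Measured compounds:
Compound 1, `O=C(N/N=C/c1cc(I)cc(I)c1O)c1ccc(C(F)(F)F)cc1`, gives 11700 nM in a functional assay on HepG2 cells (Homo sapiens) for cytotoxicity, with a stated time of 24 h; a lower number here means a stronger inhibitor, a higher number a weaker inhibitor.
Compound 2, `Cc1ccc(C(=O)NNC(=O)c2cc(I)cc(I)c2O)cc1`, gives 86400 nM in this assay.

Of these two numbers, compound 2 has the higher one, so it is the weaker inhibitor of the pair, and the gap to compound 1 lies beyond the usual scatter. Going by the values given here, the two structures differ in more than one place, so no single step links them.

Compound 3, `O=C(NNC(=O)c1cc(I)cc(I)c1O)c1ccc(Cl)cc1`, has not yet been measured. It differs from compound 2 in one place: chloro in place of methyl on an aromatic carbon. Nothing measured here shows what this exchange does in this assay, so the expectation rests on the change itself, one small group traded for another at the same spot. The expected step is a 1.2-fold lower number from compound 2 to compound 3 (0.09 log units; within the scatter), modest and of no settled direction, quite possibly within the scatter. Compound 3 is therefore estimated at 70000 nM, within a range from 25000 nM to 200000 nM.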

Compound 3, half-maximal inhibitory concentration: 48700 nM
Compound 3: middle estimate off by 1.4-fold (0.16 log units), on the high side; the range from low to high includes it.
By their numbers in this assay, from the lowest: compound 1; then compounds 3 and 2 (each within the scatter of the next).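

Placing chloro where methyl stood, on an aromatic carbon para to a large group, gives a 1.8-fold lower number from compound 2 to compound 3 (0.25 log units; within the scatter) in this assay. Going by these compounds alone, this is the first direct comparison at this position, and it shows that exchanging 4-methylphenyl for 4-chlorophenyl leaves no difference that can be told apart from ordinary repeat variation. The pair therefore offers no sign that this single exchange matters in this cell assay, and no separate measurement is available to explain the result.

Going by these compounds, only these two groups have been compared at this position, so it remains open whether an amine, a carboxylic acid or a longer chain there would move the number beyond the scatter. Compound 1 differs from compound 2 in more than one place, so which of its structural differences accounts for the gap between them also remains unresolved.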